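Aryl sulfone substituent: methyl to bromo

The compounds below may be only part of what the source reports. "The series", "measured", "known", "first", "only" and "open" are said of these compounds alone.

Measured compounds in a functional assay on PC-3 cells (Homo sapiens) for cytotoxicity, read by MTT assay, with a stated time of 72 h; a lower number here means a stronger inhibitor, a higher number a weaker inhibitor:
compound 1 `Cc1ccc(S(=O)(=O)c2nc3ccccc3nc2Nc2ccccc2)cc1`: 1060 nM
compound 2 `COc1ccc(Nc2nc3ccccc3nc2S(=O)(=O)c2ccc(C)cc2)cc1`: only a limit, > 50000 nM

Compound 1 holds the only number shown in this assay. For compound 2 the value is a limit of the assay (the limit of > 50000 nM in this assay, at which 1 of the 2 values shown sits). Among the compounds with values here, the one measured step, an at least 47-fold higher number from compound 1 to compound 2 (1.67 log units; beyond the scatter), concerns methoxy in place of hydrogen on the aniline side and does not touch the sulfonyl aryl ring changed here. Compound 3 `O=S(=O)(c1ccc(Br)cc1)c1nc2ccccc2nc1Nc1ccccc1` differs from compound 1 by bromo in place of methyl on an aromatic carbon. Within the data shown here, no measured step bears on this change, so no step beyond the scatter is expected in this assay. Compound 3 is therefore estimated at 1000 nM, range 400 nM to 2800 nM. The step of a 1.1-fold lower number from compound 1 to compound 3 (0.03 log units; within the scatter) is expected to stay within the scatter.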

Compound 3, half-maximal inhibitory concentration: 1180 nM
For compound 3 the middle estimate is 1.2-fold (0.07 log units) below the measured one; measured number inside the range.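

In this assay, 4-bromophenyl in place of 4-methylphenyl gives a 1.1-fold higher number from compound 1 to compound 3 (0.05 log units; within the scatter). Within the data shown here, this is the only reading on the sulfonyl aryl ring, and at this place the two groups cannot be told apart, whereas the earlier step concerned only the aniline side. Nothing shown gives a reason for this outcome.

From the compounds shown here alone, whether an amine, a carboxylic acid or a longer chain at this place would stay in the same range remains open. Also open, going by these compounds, is whether methoxy on the aniline ring of compound 3 would have the same outcome as in compound 2.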